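This account rests on a few compounds, and the source may have more. Where it says the series, first, only, none or still open, it means among the compounds named here.

All numbers below come from a functional assay on the whole organism (strain Wistar albino) for inhibition, with Rattus norvegicus as the target, read by paw edema, with a stated time of 1 h, at a dose of 25 mg/kg by the oral route; a lower number here means less inhibition, a higher number more inhibition at the dose given (going by the name of the read-out).

Compound 1 `O=c1c2c(Nc3ccccc3)nn(-c3ccccc3)c2nc(Nc2ccccc2)n1-c1ccccc1`: 48.1%
Compound 2 `O=c1c2c(Nc3ccc([N+](=O)[O-])cc3)nn(-c3ccccc3)c2nc(Nc2ccccc2)n1-c1ccccc1`: 29.4%
Compound 3 `Cc1ccc(Nc2nn(-c3ccccc3)c3nc(Nc4ccccc4)n(-c4ccccc4)c(=O)c23)cc1`: 55.7%

Compound 3 has the highest of the three numbers, but a number 7.6 percentage points higher from compound 1 to compound 3 (within the scatter), so compound 3 and compound 1 cannot be told apart, whereas a number 26.3 percentage points higher from compound 2 to compound 3 (beyond the scatter), a difference that does stand out.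

Compound 4 `O=c1c2c(Nc3ccc(Cl)cc3)nn(-c3ccccc3)c2nc(Nc2ccccc2)n1-c1ccccc1` has not been measured. It differs from compound 3 in one place: chloro in place of methyl on an aromatic carbon. Going by the values given here, two measured steps touch the same aromatic carbon. One is a number 18.7 percentage points lower from compound 1 to compound 2 (beyond the scatter), and the other is a number 7.6 percentage points higher from compound 1 to compound 3 (within the scatter). No chloro group has been measured, so the step to compound 4 rests on the observation that one exchange at this carbon left the number where it was and the other lowered it by a modest amount. A change between those two outcomes is therefore expected for compound 4: a small drop, most likely not beyond the scatter, and the expected step is a number 9.7 percentage points lower from compound 3 to compound 4 (within the scatter). In this assay compound 4 is estimated at 46%, with a range from 30% to 60%.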

Compound 4, a percentage reported as inhibition, in the whole organism at one dose (the size of the read-out at that dose, not a potency): 47.6%
Estimate against measurement, compound 4: 1.6 percentage points below, within the range that was stated.
By their numbers in this assay, from the lowest: compound 2; then compounds 4, 1 and 3 (each within the scatter of the next).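

In this assay, chloro in place of methyl gives a number 8.1 percentage points lower from compound 3 to compound 4 (within the scatter) and chloro in place of hydrogen gives a number 0.5 percentage points lower from compound 1 to compound 4 (within the scatter) on this aromatic carbon, so compound 1, compound 3 and compound 4 cannot be told apart. Chloro in place of nitro gives a number 18.2 percentage points higher from compound 2 to compound 4 (beyond the scatter) and thus adds a third group that stands clear of compound 2, which leaves nitro as the only one of the four groups seen here at this carbon whose compound separates from the others. No measurement in hand bears on why the nitro compound stands apart from the rest.

The compounds shown leave open whether a methoxy group, an amine or a carboxylic acid on this carbon would group with hydrogen, methyl and chloro or with nitro. All four compounds share the rest of their structure and were read at one dose and one time, so changes elsewhere on the core, and the behaviour of these compounds at other doses or times, also remain open.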